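This account rests on a few compounds, and the source may have more. Where it says the series, first, only, none or still open, it means among the compounds named here.

Compound 1 `Cc1ccc(S(=O)(=O)Oc2ccc3c(c2C)[C@H](Cn2cc(-c4ccc(Cl)cc4)nn2)[C@@]24CC(=O)[C@@](C)(CC[C@@H]32)C4)cc1` and compound 2 `Cc1ccc(S(=O)(=O)Oc2ccc3c(c2C)[C@H](Cn2cc(-c4ccc(Br)cc4)nn2)[C@@]24CC(=O)[C@@](C)(CC[C@@H]32)C4)cc1` share one core and differ only in the group on the six-membered aromatic ring of carbon only, chloro against bromo. In a functional assay on A549 cells (Homo sapiens) for cytotoxicity, read by MTT assay, with a stated time of 4 days (a lower number here means a stronger inhibitor, a higher number a weaker inhibitor), compound 1 gives only a limit of the assay, > 20000 nM. In this assay compound 2 likewise gives only a limit, > 20000 nM. The step that the two limits leave unreadable from compound 1 to compound 2 is therefore not readable as a number; what the pair shows is the limit of > 20000 nM in this assay, at which 2 of the 2 values shown sit, nothing more. Compound 3 `Cc1ccc(S(=O)(=O)Oc2ccc3c(c2C)[C@H](Cn2cc(-c4ccc(C(F)(F)F)cc4)nn2)[C@@]24CC(=O)[C@@](C)(CC[C@@H]32)C4)cc1` is the next member of the series: trifluoromethyl in place of bromo on an aromatic carbon. Among the compounds with values here, no measured step bears directly on this change, and the one step in hand, from chloro to bromo, gives no size because both values sit at the limit of > 20000 nM in this assay, at which 2 of the 2 values shown sit. Two halogens of different size have left the value at the limit, so no reading beyond the scatter is expected from the trifluoromethyl either. Compound 3 is expected to give an estimated 30000 nM in this assay, most likely again reported only as a limit, within 8000 nM to 100000 nM. The expected step that the limit leaves unreadable from compound 2 to compound 3 is thus an estimate from a limit, not from a measured difference.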

Compound 3, half-maximal inhibitory concentration: > 20000 nM
Compound 3: no number, only a limit; the forecaster's own chance of this, stated with the estimate: 85%; the middle value lies beyond the limit too.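

Within the data shown here, no step among compound 1, compound 2 and compound 3 can be read in this assay, and the three compounds share only one reading: the limit of > 20000 nM in this assay, at which 3 of the 3 values shown sit. The compounds shown leave open whether any other group at this place, or any change elsewhere on the shared core, would give a readable number in this assay.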